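A Benzyl Ester Step Repeated on a Second Core

A few compounds are considered here, and "the series" means these few. Any claim that something is new, unique, unknown or untested is made for them only; others in the source may bear on it.

The study concerns a small set of phenol-bearing esters tested in a functional assay on Jurkat cells (Homo sapiens) for cytotoxicity, with a stated time of 72 h; on this read-out higher numbers stand for an effect only at larger amounts of compound and lower numbers for an effect already at smaller amounts. Compound 1 `C=C[C@@](C)(/C=C/c1ccc(O)cc1)CC/C=C(C)/C=C/C(=O)OCC` carries an ethoxycarbonyl group on a long unsaturated chain. In this assay compound 1 reaches only the limit of the assay, > 49000 nM. Compound 2 `C=C[C@@](C)(/C=C/c1ccc(O)cc1)CC/C=C(C)/C=C/C(=O)OCc1ccccc1` differs from compound 1 by phenyl in place of methyl on a saturated chain carbon bound to an oxygen next to a carbonyl group. In this assay compound 2 also stops at the limit, > 49000 nM. The step that the two limits leave unreadable from compound 1 to compound 2 therefore cannot be read in size: both values are limits. Compound 3 `C=C[C@@](C)(/C=C/c1ccc(O)c(/C=C/C(=O)OCC)c1)CCC=C(C)C` places the ethoxycarbonyl-bearing chain on the aromatic ring instead; the difference between the two cores is not broken down here. In this assay compound 3 again sits at the limit, > 49000 nM.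

Compound 4 `C=C[C@@](C)(/C=C/c1ccc(O)c(/C=C/C(=O)OCc2ccccc2)c1)CCC=C(C)C` has not been measured. It differs from compound 3 by phenyl in place of methyl on a saturated chain carbon bound to an oxygen next to a carbonyl group, the same change that takes compound 1 to compound 2. In this assay the step that the limit leaves unreadable from compound 3 to compound 4 is expected to be unreadable in the same way, since all measured compounds share the one finding the limit of > 49000 nM in this assay, at which 3 of the 3 values shown sit, and the earlier step that the two limits leave unreadable from compound 1 to compound 2 gave no readable shift. For compound 4 the expected value in this assay is 80000 nM, with a range from 30000 nM to 300000 nM, and most likely the assay will once more report only a limit.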

Compound 4, half-maximal effective concentration: > 49000 nM
Compound 4: a limit, no number (the forecaster's own chance of this, stated with the estimate: 85%); the middle value does not contradict the limit.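

In this assay, for the compounds shown here, compound 4 gives > 49000 nM, a limit of the assay and not a number, so neither the step from compound 1 to compound 2 nor the one from compound 3 to compound 4 can be read in size. The compounds shown share one finding: the limit of > 49000 nM in this assay, at which 4 of the 4 values shown sit. They leave open whether ethoxycarbonyl to benzyloxycarbonyl shifts the effect on either core, and how the two cores compare.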